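Halogen to isopropyl at the distal ring of the arylimidazoline series

The compounds below may be only part of what the source reports. "The series", "measured", "known", "first", "only" and "open" are said of these compounds alone.

Of the compounds shown here, two have been measured in an assay for binding affinity to Adrenergic receptor alpha-1 (Rattus norvegicus); on this read-out lower numbers stand for stronger inhibition and higher numbers for weaker inhibition. Compound 1 `Cc1c(NC2=NCCN2)cccc1-c1cccc(F)c1` gives 275 nM in this assay. Compound 2 `Cc1c(NC2=NCCN2)cccc1-c1cccc(Cl)c1` gives 132 nM in this assay. Within the data shown here, the only step so far, a 2.1-fold lower number from compound 1 to compound 2 (0.32 log units; beyond the scatter), is a modest gain on exchanging one halogen for a heavier one, and it leaves compound 2 with the lowest of the two numbers, compound 1 standing beyond the scatter above it.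

Compound 3 `Cc1c(NC2=NCCN2)cccc1-c1cccc(C(C)C)c1` is not yet measured. It differs from compound 2 in one place: isopropyl in place of chloro on an aromatic carbon. Among the measured compounds shown here, the single measured step bears on this change only loosely, since it compared two halogens and the new group is an alkyl of three heavy atoms. For the measured compounds named here, no step has tested an alkyl at this carbon, so the expected direction rests on the trend from compound 1 to compound 2 alone. As far as these compounds go, a further modest lowering of the number is expected, with the range held wide because the step is untested; the estimated step is a 1.3-fold lower number from compound 2 to compound 3 (0.12 log units; within the scatter), giving compound 3 an expected value of 100 nM, between 35 nM and 300 nM.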

Compound 3, inhibition constant: 1200 nM
For compound 3 the middle estimate is 12-fold (1.08 log units) below the measured one; the whole stated range lies below it.
By their numbers in this assay, from the lowest: compound 2; then compound 1; then compound 3.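

In this assay the lowering seen between the two halogens does not carry over to an alkyl group at this aromatic carbon, meta to a large group: a 9.1-fold higher number from compound 2 to compound 3 (0.96 log units; beyond the scatter) runs in the opposite direction and is much the larger of the steps read so far. The change is not specific to the chloro compound either, since a 4.4-fold higher number from compound 1 to compound 3 (0.64 log units; beyond the scatter) places isopropyl behind fluoro as well, so both halogens give lower numbers than isopropyl and the order among the three groups cannot be extended from the halogen step alone. Nothing available here accounts for this reversal.

The compounds shown leave open whether the higher number belongs to alkyl groups at this carbon in general or to the branched isopropyl group in particular, a question that a methyl group, an ethyl group or a straight propyl chain could address. They also leave open how non-halogen, non-alkyl replacements such as a methoxy group or a nitrile would stand against the chloro of compound 2 on this read-out.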